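The source may report more compounds than this note shows. Statements on the series, on what has been measured and on what is new or still open speak of the compounds shown alone.

Of the compounds shown here, three built on one shared core have been measured in an assay on isolated protein for inhibition of Alpha glucosidase (Homo sapiens), with stated times of 5 min and 15 min, tested at 50 uM; a higher number here means more inhibition at the concentration tested (going by the name of the read-out), a lower number less inhibition. Compound 3 `O=C1/C(=C/c2ccccc2)CCC/C1=C\c1cccc(O)c1` gives 65.1%, the highest of the three numbers. Compound 1 `O=C1/C(=C/c2ccccc2)CCC/C1=C\c1ccc(O)cc1` gives 53%, and compound 2 `O=C1/C(=C/c2ccccc2)CCC/C1=C\c1ccc(Br)cc1` gives 29.1%. Every step between them lies beyond the usual scatter: a number 12.1 percentage points higher from compound 1 to compound 3 (beyond the scatter), with 3-hydroxyphenyl in place of 4-hydroxyphenyl; a number 23.9 percentage points lower from compound 1 to compound 2 (beyond the scatter), with bromo in place of hydroxy on an aromatic carbon; and a number 36 percentage points higher from compound 2 to compound 3 (beyond the scatter), with 3-hydroxyphenyl in place of 4-bromophenyl.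

Compound 4 `Cc1cccc(/C=C2\CCC/C(=C\c3ccccc3)C2=O)c1` has not yet been measured in this assay. It differs from compound 3 in one place: methyl in place of hydroxy on an aromatic carbon. The measured step that bears on this is the one in which hydroxy also left an aromatic carbon, and there the number moved by a modest amount, a number 23.9 percentage points lower from compound 1 to compound 2 (beyond the scatter). The group now entering brings no hydrogen-bond donor and no acceptor, just as the earlier exchange removed both. Because a number 23.9 percentage points lower from compound 1 to compound 2 (beyond the scatter) followed the loss of hydroxy, a fall of a similar size is expected for compound 4 in this assay, amounting to a number 23.1 percentage points lower from compound 3 to compound 4 (beyond the scatter). The estimate for compound 4 is therefore 42%, with a range from 25% to 60%.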

Compound 4, a percentage reported as inhibition, at one concentration (the size of the read-out at that concentration, not a potency): 47.9%
Estimate against measurement, compound 4: 5.9 percentage points below, and the stated range covers the measured number.
By their numbers in this assay, from the lowest: compound 2; then compounds 4 and 1 (each within the scatter of the next); then compound 3.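

Putting methyl in place of hydroxy on an aromatic carbon, meta to a large group, gives a number 17.2 percentage points lower from compound 3 to compound 4 (beyond the scatter) in this assay, so at this place the two groups are not interchangeable even though each adds one heavy atom. Yet hydroxy is not needed for inhibition here: the 3-methylphenyl compound gives a number 18.8 percentage points higher from compound 2 to compound 4 (beyond the scatter), and a number 5.1 percentage points lower from compound 1 to compound 4 (within the scatter) means that it cannot be told apart from the 4-hydroxyphenyl compound, despite having no hydrogen-bond donor or acceptor in that group. Nothing measured here explains why these numbers differ.

The step from compound 2 to compound 4 changes both the group and where it sits, so the effect of each remains unseparated; a matching 3-bromophenyl or 4-methylphenyl compound would be needed to pull them apart. Going by these compounds, it also remains open whether a methoxy group or an amine at this place would give a number closer to that of compound 3 or to that of compound 4, which would show more clearly what the hydroxy contributes.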